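Phenyl for methoxypyridyl on the shared core: compound 4

The compounds below may be only part of what the source reports. "The series", "measured", "known", "first", "only" and "open" are said of these compounds alone.

Compound 2 `COc1cncc(-c2ccnc3c2c(C(C)C)nn3-c2ccc(C(N)=O)c(N[C@H]3CC[C@H](O)CC3)c2)c1` gives the lowest number of the three measured in a functional assay on SK-BR-3 cells (Homo sapiens) for inhibition, read by CellTiter-Glo, with a stated time of 72 h (on this read-out higher numbers stand for weaker inhibition and lower numbers for stronger inhibition), namely 451 nM. Compound 1 `CNc1cc(-n2nc(C(C)C)c3c(-n4cnc(-c5cnn(C)c5)c4)ccnc32)ccc1C(N)=O` gives 773 nM in this assay, which lies within the scatter of compound 2. Compound 3 `CC(C)c1nn(-c2ccc(C(N)=O)cc2)c2nccc(-n3cnc(-c4cnn(C)c4)c3)c12` gives 1640 nM in this assay, and its gap to compound 2 lies beyond the scatter. Within the data shown here, the one single-point step among the measured compounds is a 2.1-fold higher number from compound 1 to compound 3 (0.33 log units; beyond the scatter), which concerns the substituent on the benzamide ring and not the aryl group on the shared core.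

Compound 4 `CC(C)c1nn(-c2ccc(C(N)=O)c(N[C@H]3CC[C@H](O)CC3)c2)c2nccc(-c3ccccc3)c12` differs from compound 2 by phenyl in place of 5-methoxypyridin-3-yl on an aromatic carbon. Among the measured compounds shown here, no measured pair isolates a change at this position: compound 1 and compound 2 differ there as well, but they also differ in the group on the benzamide ring, so the value of compound 1, 773 nM, and that of compound 2, 451 nM, cannot be read as a step for the aryl group alone. The expectation therefore rests on general experience with the series rather than on a measured step. The loss of both hydrogen-bond acceptors is expected to cost some inhibition, so a modest step of a 1.9-fold higher number from compound 2 to compound 4 (0.28 log units; within the scatter) toward a higher number is expected. For compound 4 the estimate in this assay is 850 nM, with a range from 300 nM to 2500 nM.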

Compound 4, half-maximal inhibitory concentration: > 10000 nM
Compound 4: no number, only a limit; the forecaster's own chance of this, stated with the estimate: 3%; at least 11-fold (1.07 log units) between middle value and limit.
By their numbers in this assay, from the lowest: compounds 2 and 1 (each within the scatter of the next); then compound 3. At a limit, above all of these: compound 4.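

Among these compounds, the first reading in this assay that isolates this carbon of the shared core, with the group on the benzamide ring held constant, is an at least 22-fold higher number from compound 2 to compound 4 (1.34 log units; beyond the scatter). Compound 4 carries a limit of the assay and not a number, so this step has a floor but no measured size: the limit of > 10000 nM in this assay, at which 1 of the 4 values shown sits. Among the compounds shown here, exchanging 5-methoxypyridin-3-yl, with 2 hydrogen-bond acceptors, for phenyl, with 0, therefore gives a large step at this aromatic carbon, whereas the only earlier single-place step, a 2.1-fold higher number from compound 1 to compound 3 (0.33 log units; beyond the scatter), is modest and lies on the benzamide ring.

The two compounds do not separate the contribution of the ring nitrogen from that of the methoxy group, since both leave together in this change; a plain pyridyl ring without the methoxy group and a methoxyphenyl ring would each take away only one of them. Also open, as far as these compounds go, is whether the same step holds with the methylamino group of compound 1 on the benzamide ring, and whether a hydroxyl, an amine or a fluorine on the phenyl ring of compound 4 would bring back a number inside the range of the assay.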